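A few compounds are considered here, and "the series" means these few. Any claim that something is new, unique, unknown or untested is made for them only; others in the source may bear on it.

Working notes on the series in a functional assay on KB cells (Homo sapiens) for antiproliferative activity, read by sulforhodamine B assay, with a stated time of 3 days; a higher number here means that more compound is needed for the effect, a lower number that less compound is needed. Compound 1 `CCC1=C(O)c2c(oc(-c3ccccc3)cc2=O)C(CC)(CC)C1=O` gives > 236 uM, which is a limit of the assay. Among the compounds with values here, compound 2 `CCC1=C(O)c2c(oc(-c3cccc(C)c3)cc2=O)C(CC)(CC)C1=O` gives 49.7 uM, and compound 3 `CCC1=C(O)c2c(oc(-c3cccc(OC)c3)cc2=O)C(CC)(CC)C1=O` gives 13.3 uM, the lowest number so far.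

Compound 4 `CCC1=C(O)c2c(oc(-c3cccc(OC(F)(F)F)c3)cc2=O)C(CC)(CC)C1=O` differs from compound 3 as follows: trifluoromethyl in place of methyl on an oxygen on an aromatic ring. Within the data shown here, three measured steps bear on this: an at least 4.7-fold lower number from compound 1 to compound 2 (0.67 log units; beyond the scatter), an at least 17-fold lower number from compound 1 to compound 3 (1.24 log units; beyond the scatter) and a 3.7-fold lower number from compound 2 to compound 3 (0.57 log units; beyond the scatter). None of them changes the group on that oxygen, so they guide only loosely. A modest step toward a higher number is expected in this assay. The estimated step is a 1.8-fold higher number from compound 3 to compound 4 (0.26 log units; within the scatter). For compound 4 the expected value is 24 uM, with an estimated range of 7 uM to 80 uM.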

Compound 4, concentration for half-maximal effect: > 47.4 uM
Compound 4: a limit, no number (the forecaster's own chance of this, stated with the estimate: 10%); at least 1.9-fold (0.29 log units) between middle value and limit.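

In this assay, the group on the oxygen on an aromatic ring matters, not only the presence of an oxygen there: methoxy to trifluoromethoxy gives an at least 3.5-fold higher number from compound 3 to compound 4 (0.55 log units; beyond the scatter). Compound 4 gives > 47.4 uM, which is a limit of the assay and not a number. The steps from compound 1 and compound 2 to compound 4 cannot be read because of limits: the limit of > 47.4 uM in this assay, at which 1 of the 4 values shown sits.

From the compounds shown here alone, how far the number moves with trifluoromethyl in place of methyl therefore stays open. The compounds shown also leave open how a longer chain on that oxygen, or an amine in place of the methoxy, would read in this assay.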